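Replacing the Aryl Group of Compound 2 with Acetamido

This account rests on a few compounds, and the source may have more. Where it says the series, first, only, none or still open, it means among the compounds named here.

Compound 1 `O=C1Nc2ccc(S(=O)(=O)N3CCOCC3)cc2/C1=N/c1ccc(Br)cc1`: 15300 nM
Compound 2 `Cc1ccc(/N=C2\C(=O)Nc3ccc(S(=O)(=O)N4CCOCC4)cc32)cc1`: 18900 nM
Compound 3 `COc1ccc(-c2c(C#N)c(N)n(/N=C3\C(=O)Nc4ccc(S(=O)(=O)N5CCOCC5)cc43)c(=O)c2C#N)cc1`: 18100 nM

All three compounds were tested in a functional assay on HCT-116 cells (Homo sapiens) for cytotoxicity, read by sulforhodamine B assay, with a stated time of 24 h; on this read-out higher numbers stand for weaker inhibition and lower numbers for stronger inhibition. Compound 2 stands level with the other two, as its value lies within the scatter of both compound 1 and compound 3. The next compound, compound 4 `CC(=O)N/N=C1\C(=O)Nc2ccc(S(=O)(=O)N3CCOCC3)cc21`, keeps the shared core but differs from compound 2 on a double-bonded nitrogen: acetamido in place of 4-methylphenyl on a double-bonded nitrogen. In words, acetamido takes the place of 4-methylphenyl. For the measured compounds named here, no measured step makes this exchange itself. The closest evidence is a 1.2-fold higher number from compound 1 to compound 2 (0.09 log units; within the scatter), which comes from methyl in place of bromo on an aromatic carbon. Compound 3 also matters, since its value of 18100 nM shows no separation from that of compound 2. No change beyond the scatter is therefore expected in this assay, though this rests on thin evidence. The expected change is a 1.1-fold higher number from compound 2 to compound 4 (0.02 log units; within the scatter). For compound 4, the estimated value is 20000 nM, with an expected range from 8000 nM to 50000 nM.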

Compound 4, half-maximal inhibitory concentration: 29000 nM
For compound 4 the middle estimate is 1.5-fold (0.16 log units) below the measured one, within the range that was stated.
By their numbers in this assay, from the lowest: compounds 1, 3, 2 and 4 (each within the scatter of the next).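

In this assay, acetamido in place of 4-methylphenyl gives a 1.5-fold higher number from compound 2 to compound 4 (0.19 log units; within the scatter) and acetamido in place of 4-bromophenyl gives a 1.9-fold higher number from compound 1 to compound 4 (0.28 log units; within the scatter), and both steps lie within the scatter. For the compounds shown here, the place on the double-bonded nitrogen therefore accepts a group with no ring and with a hydrogen-bond donor instead of a six-membered aromatic ring without a separation in the values, whereas the only earlier step, methyl in place of bromo on an aromatic carbon, had kept that ring in place. No measurement shown gives an explanation for this result.

The compounds shown leave open whether any group at this place would separate from these values. An amine, a carboxylic acid or a longer chain in place of acetamido could answer that.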